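Replacing a tert-Butyl Group with Methoxy: Expected Cytotoxicity

A few compounds are considered here, and "the series" means these few. Any claim that something is new, unique, unknown or untested is made for them only; others in the source may bear on it.

Compound 1 `CC(C)(C)c1ccc(-n2nc(-c3ccc(C(F)(F)F)cc3O)nc2-c2ccccc2O)cc1` gives 67.3% in a functional assay on PC-12 cells (Rattus norvegicus) for cytotoxicity, read by MTT assay, with stated times of 2 h and 24 h, tested at 1 uM; on this read-out higher numbers stand for a stronger effect at the one concentration tested and lower numbers for a weaker effect. Compound 2 `Oc1cc(C(F)(F)F)ccc1-c1nc(-c2ccccc2O)n(-c2ccc(F)cc2)n1` gives 67.2% in this assay, and the step of a number 0.1 percentage points lower from compound 1 to compound 2 (within the scatter) shows that the two numbers lie within the usual scatter of each other, so neither can be called stronger. Compound 3 `COc1ccc(-n2nc(-c3ccc(C(F)(F)F)cc3O)nc2-c2ccccc2O)cc1` is not yet measured; it differs from compound 1 by methoxy in place of tert-butyl on an aromatic carbon. For the measured compounds named here, the one measured step that bears on this change, a number 0.1 percentage points lower from compound 1 to compound 2 (within the scatter), alters the same place on the ring and stays within the scatter, so no step beyond the scatter is expected here either. Compound 3 is therefore estimated to give 66% in this assay, between 55% and 77%, an expected step of a number 1.3 percentage points lower from compound 1 to compound 3 (within the scatter).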

Compound 3, a percentage reported as activity, at one concentration (the size of the read-out at that concentration, not a potency): 69%
The estimate for compound 3 lay 3 percentage points below the measured number; the measured number falls inside the stated range.
By their numbers in this assay, from the lowest: compounds 2, 1 and 3 (each within the scatter of the next).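

In this assay, methoxy in place of tert-butyl gives a number 1.7 percentage points higher from compound 1 to compound 3 (within the scatter) and methoxy in place of fluoro gives a number 1.8 percentage points higher from compound 2 to compound 3 (within the scatter). This place on the ring has now taken three different groups, including one with an oxygen atom and a hydrogen-bond acceptor, without any step beyond the scatter at this one concentration. No measurement here offers an explanation for this. Going by these compounds, an amine, a carboxylic acid or a longer chain at this place remains open, as does whether these three groups would separate at other concentrations.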